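Swapping the aryl group on a urea-type inhibitor

The source may report more compounds than this note shows. Statements on the series, on what has been measured and on what is new or still open speak of the compounds shown alone.

Compound 1 `COc1cccc(NC(=O)Nc2nc(-c3cc4ccccc4o3)cs2)c1` measures 200 nM
Compound 2 `O=C(Nc1nc(-c2cc3cc(Br)ccc3o2)cs1)Nc1ccccc1F` measures > 200000 nM

Compound 2 stands at a limit of a physicochemical assay, with a stated time of 6 min (a lower number here means a stronger inhibitor, a higher number a weaker inhibitor), and has no exact number (> 200000 nM). Compound 3 `COc1cccc(NC(=O)Nc2nc(-c3cc4cc(Br)ccc4o3)cs2)c1` has 3-methoxyphenyl in place of 2-fluorophenyl on an amide-type nitrogen. Among the measured compounds shown here, no measured pair shows this change alone, so the expectation is a judgement. Compound 1 also carries 3-methoxyphenyl and gives a far lower reading in this assay (200 nM). A large fall in the number, meaning stronger inhibition, is therefore expected (an at least 330-fold lower number from compound 2 to compound 3 (2.52 log units; beyond the scatter)). Compound 3 is estimated at 600 nM (range 60 nM to 20000 nM).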

Compound 3, half-maximal inhibitory concentration: > 200000 nM
Compound 3 ended at the assay's limit (the forecaster's own chance of this, stated with the estimate: 15%); at least 330-fold (2.52 log units) between middle value and limit.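

With 3-methoxyphenyl held fixed, bromo in place of hydrogen on an aromatic carbon gives, in this assay, an at least 1000-fold higher number from compound 1 to compound 3 (3.00 log units; beyond the scatter). On the core of compound 1, this single change is therefore enough to lose measurable inhibition, and 3-methoxyphenyl does not restore it when the bromo is present. The swap of 2-fluorophenyl for 3-methoxyphenyl cannot be read, because compound 2 and compound 3 both end at a limit rather than a number: the limit of > 200000 nM in this assay, at which 2 of the 3 values shown sit.

As far as these compounds go, whether chloro or an amine on that aromatic carbon would keep a measurable reading remains open. So does how 2-fluorophenyl behaves without the bromo.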